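A few compounds are considered here, and "the series" means these few. Any claim that something is new, unique, unknown or untested is made for them only; others in the source may bear on it.

In a physicochemical assay for lipophilicity, using the shake flask method, in phosphate buffer, measured as octanol-water partition, with a stated time of 30 min, at pH 7.4 (a higher number here means a more lipophilic compound, a lower number a more polar compound), compound 1 `O=C(Nc1ccccc1)c1cnc(NCc2c(F)ccc3c2CCO3)n2cnnc12` gives 4.1, the higher of the two numbers in hand; compound 2 `Cc1cc(-c2cnc(NCc3c(F)ccc4c3CCO4)c3cn[nH]c(=O)c23)n(C)n1` gives 3, a gap that lies beyond the usual scatter of this measurement. Compound 3 `O=C(Nc1cnc(NCc2c(F)ccc3c2CCO3)n2cnnc12)c1cccnc1` is not yet measured. It differs from compound 1 in one place: ((pyridin-3-yl)carbonyl)amino in place of phenylcarbamoyl on an aromatic carbon. Going by the values given here, no measured pair tracks this change, so the step can only be estimated. A move to a lower number, beyond the scatter, is expected, estimated at a number 1.00 log units lower from compound 1 to compound 3 (beyond the scatter). Compound 3 is therefore expected to give about 3.1, with a likely range from 2.4 to 3.8.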

Compound 3, distribution coefficient: 2
Estimate against measurement, compound 3: 1.10 log units above; the whole stated range lies above it.
By their numbers in this assay, from the lowest: compound 3; then compound 2; then compound 1.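

In this assay, this aromatic carbon proves sensitive to the group it carries: ((pyridin-3-yl)carbonyl)amino in place of phenylcarbamoyl gives a number 2.10 log units lower from compound 1 to compound 3 (beyond the scatter), a large step for an exchange of equal heavy-atom count. The exchange alters two features at once, placing a hetero atom in the six-membered aromatic ring and turning the amide link on the core. Nothing at hand accounts for the size of the step.

As far as these compounds go, how the step divides between those two features remains open. Benzoylamino or (pyridin-3-yl)carbamoyl on the same carbon would separate them.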